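Varying the ester group on a shared flavonoid core

The source may report more compounds than this note shows. Statements on the series, on what has been measured and on what is new or still open speak of the compounds shown alone.

Compound 1 `COc1cc(C2Oc3cc([C@H]4Oc5cc(O)cc(O)c5C(=O)[C@@H]4O)ccc3OC2COC(=O)c2ccc(N)cc2)ccc1O` carries a 4-aminophenyl group on the ester carbonyl of the shared core. Within the data shown here, in a functional assay, read by spectrophotometry, with a stated time of 30 min (a lower number here means that less compound is needed, a higher number that more compound is needed for the effect), compound 1 gives 128000 nM, the highest of the three numbers measured so far, though the two others lie within the scatter of it. Compound 2 `COc1cc(C2Oc3cc([C@H]4Oc5cc(O)cc(O)c5C(=O)[C@@H]4O)ccc3OC2COC(=O)c2cc(OC)c(OC)c(OC)c2)ccc1O` gives 94800 nM in this assay, and compound 3 `CCOC(=O)CC(=O)OCC1Oc2ccc([C@H]3Oc4cc(O)cc(O)c4C(=O)[C@@H]3O)cc2OC1c1ccc(O)c(OC)c1` gives 101000 nM. The step of a 1.4-fold lower number from compound 1 to compound 2 (0.13 log units; within the scatter) and the step of a 1.3-fold lower number from compound 1 to compound 3 (0.10 log units; within the scatter) both exchange the group on the carbonyl carbon, and neither reaches beyond the scatter.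

Compound 4 `COc1cc(C2Oc3cc([C@H]4Oc5cc(O)cc(O)c5C(=O)[C@@H]4O)ccc3OC2COC(=O)/C=C/c2ccc(C)cc2)ccc1O` differs from compound 1 by 2-(4-methylphenyl)ethenyl in place of 4-aminophenyl on a carbonyl carbon. This change sits at the same carbonyl carbon as the two measured steps, each of which left the number essentially unchanged. He therefore expects no step beyond the scatter in this assay, with the estimated step of a 1.2-fold lower number from compound 1 to compound 4 (0.07 log units; within the scatter) small and uncertain in direction. For compound 4 he estimates a value of 110000 nM, within a range from 50000 nM to 250000 nM.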

Compound 4, half-maximal effective concentration: 136000 nM
Compound 4: the middle estimate sits 1.2-fold (0.09 log units) below what was measured, and the stated range covers the measured number.
By their numbers in this assay, from the lowest: compounds 2, 3, 1 and 4 (each within the scatter of the next).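

In this assay, among these compounds, the 2-(4-methylphenyl)ethenyl group, with its double bond outside aromatic rings and no hydrogen-bond donor or acceptor, gives a 1.1-fold higher number from compound 1 to compound 4 (0.03 log units; within the scatter) and also a 1.3-fold higher number from compound 3 to compound 4 (0.13 log units; within the scatter) and a 1.4-fold higher number from compound 2 to compound 4 (0.16 log units; within the scatter) so no step at this carbonyl carbon yet leaves the scatter. The four groups now compared, 4-aminophenyl, 3,4,5-trimethoxyphenyl, (ethoxycarbonyl)methyl and 2-(4-methylphenyl)ethenyl, cannot be told apart by this read-out, and this holds even when the hydrogen-bond donor of 4-aminophenyl is exchanged for a group without one. Nothing available accounts for this flat picture.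

Going by these compounds, whether a carboxylic acid or a tertiary amine on a longer chain at this carbonyl carbon would step beyond the scatter stays open. So does whether any change elsewhere on the shared core would do so.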